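A hydroxy group in place of methyl

The source may report more compounds than this note shows. Statements on the series, on what has been measured and on what is new or still open speak of the compounds shown alone.

compound 1 `COc1cc(-c2cccc3nc(-c4ccccc4)oc23)cc(OC)c1OC`: 6800 nM
compound 2 `COc1cc(-c2cccc3nc(-c4cccc(Cl)c4)oc23)cc(OC)c1OC`: > 25000 nM (a limit of the assay)
compound 3 `COc1cc(-c2cccc3nc(-c4cccc(C)c4)oc23)cc(OC)c1OC`: > 25000 nM (a limit of the assay)

In a functional assay on NCI-H460 cells (Homo sapiens) for antiproliferative activity, read by MTT assay, with a stated time of 48 h (on this read-out higher numbers stand for weaker inhibition and lower numbers for stronger inhibition), compound 3 stands at the limit of > 25000 nM in this assay, at which 2 of the 3 values shown sit. Compound 4 `COc1cc(-c2cccc3nc(-c4cccc(O)c4)oc23)cc(OC)c1OC` differs from it in one place: hydroxy in place of methyl on an aromatic carbon. This is hydroxy in place of methyl on an aromatic carbon.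

Going by the values given here, two measured steps bear on this position. Methyl in place of hydrogen gave an at least 3.6-fold higher number from compound 1 to compound 3 (0.56 log units; beyond the scatter). Chloro in place of hydrogen gave an at least 3.6-fold higher number from compound 1 to compound 2 (0.56 log units; beyond the scatter). Neither step tests hydroxy, so only a small move towards lower numbers is expected, and compound 4 may well stay at the limit.

The expected step is an at least 1.3-fold lower number from compound 3 to compound 4 (0.14 log units; that floor lies within the scatter). For compound 4 the estimate is 18000 nM, with an expected range from 5000 nM to 40000 nM.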

Compound 4, half-maximal inhibitory concentration: 1900 nM
Compound 4: middle estimate off by 9.5-fold (0.98 log units), on the high side; measured number below the stated range.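

In this assay this position is not simply closed to substitution: hydroxy gave a 3.6-fold lower number from compound 1 to compound 4 (0.55 log units; beyond the scatter), whereas methyl and chloro had both moved the number upward. The gap to those two groups is wider still, with an at least 13-fold lower number from compound 3 to compound 4 (1.11 log units; beyond the scatter) and an at least 13-fold lower number from compound 2 to compound 4 (1.11 log units; beyond the scatter). These two steps give only floors, as compound 2 and compound 3 each sit at a limit of the assay: the limit of > 25000 nM in this assay, at which 2 of the 4 values shown sit.

As far as these compounds go, whether this gain belongs to hydroxy alone remains open, as an amine or a carboxylic acid at the same place could match or exceed it. The compounds shown also leave open whether hydroxy would help elsewhere on this ring.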